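Chain extension on the thioether of the chloromethyl ketone series

This account rests on a few compounds, and the source may have more. Where it says the series, first, only, none or still open, it means among the compounds named here.

Three compounds share the chloromethyl ketone core and differ only in the thioether chain. Compound 1 `CCCCCSC[C@H](NC(C)=O)C(=O)CCl` gives 5800 nM in a functional assay on NALM-6 cells (Homo sapiens); a higher number here means a weaker inhibitor, a lower number a stronger inhibitor. Compound 2 `CCCCCCCCCCSC[C@H](NC(C)=O)C(=O)CCl` gives 4700 nM in this assay, and compound 3 `CCCCCCCCCCCSC[C@H](NC(C)=O)C(=O)CCl` gives 1700 nM. The step of a 1.2-fold lower number from compound 1 to compound 2 (0.09 log units; within the scatter) is within the scatter, whereas a 3.4-fold lower number from compound 1 to compound 3 (0.53 log units; beyond the scatter) and a 2.8-fold lower number from compound 2 to compound 3 (0.44 log units; beyond the scatter) are both beyond it. Compound 3 therefore stands lowest of the three, with compound 2 nearest and compound 1 furthest.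

Compound 4 `CCCCCCCCCCCCCCSC[C@H](NC(C)=O)C(=O)CCl` carries the change (propyl in place of hydrogen on a saturated chain carbon, ten or more bonds along the chain from a sulfur). Going by the values given here, both steps beyond the scatter in this assay, a 3.4-fold lower number from compound 1 to compound 3 (0.53 log units; beyond the scatter) and a 2.8-fold lower number from compound 2 to compound 3 (0.44 log units; beyond the scatter), went in the direction of a lower number on lengthening the chain, and the only step that did not, a 1.2-fold lower number from compound 1 to compound 2 (0.09 log units; within the scatter), stayed within the scatter. Extending the chain further by propyl is expected to continue the modest downward direction rather than to reverse it, though three points give no firm size. Compound 4 is therefore estimated at 900 nM, in the range 400 nM to 2500 nM, which means an expected step of a 1.9-fold lower number from compound 3 to compound 4 (0.28 log units; within the scatter) in this assay.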

Compound 4, half-maximal inhibitory concentration: 8700 nM
For compound 4 the middle estimate is 9.7-fold (0.99 log units) below the measured one; the measured number lies above the stated range.
By their numbers in this assay, from the lowest: compound 3; then compounds 2, 1 and 4 (each within the scatter of the next).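

Lengthening the thioether chain does not keep lowering the number in this assay: propyl in place of hydrogen on a saturated chain carbon, ten or more bonds along the chain from a sulfur, gives a 5.1-fold higher number from compound 3 to compound 4 (0.71 log units; beyond the scatter). This reverses the direction seen up to compound 3, so the response to chain length at this position is not a steady one, and compound 3 is now the strongest inhibitor of the four, with its steps to compounds 1, 2 and 4 all beyond the scatter. The other new step, a 1.9-fold higher number from compound 2 to compound 4 (0.27 log units; within the scatter), lies within the scatter, so the added carbons of compound 4 give up the gain seen at compound 3 and leave no separable difference from compound 2.

The four compounds leave open whether the turn is sharp or gradual, which a dodecyl or a tridecyl chain on the same core would show. They also leave open whether the long chain must stay purely hydrocarbon, which a terminal amine or carboxylic acid on the undecyl chain of compound 3 would test. No supporting data explain the rise at compound 4.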